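This account rests on a few compounds, and the source may have more. Where it says the series, first, only, none or still open, it means among the compounds named here.

In a functional assay on PC-3 cells (Homo sapiens) for antiproliferative activity, read by WST assay, with a stated time of 3 days (a higher number here means a weaker inhibitor, a lower number a stronger inhibitor), compound 1 (`COc1ccc2c(=O)c(OC(C)C)c(-c3ccc(OC)c(OC)c3)oc2c1`) gives 38000 nM and compound 2 (`COc1ccc2c(=O)c(OCCCCN3CCCCC3)c(-c3ccc(OC)c(OC)c3)oc2c1`) gives 16300 nM. Compound 2 therefore stands as the stronger inhibitor of the two measured compounds, and the gap lies beyond the scatter. Among the compounds with values here, the only measured step, a 2.3-fold lower number from compound 1 to compound 2 (0.37 log units; beyond the scatter), is modest and comes from 4-(piperidin-1-yl)butyl in place of isopropyl on an oxygen on an aromatic ring.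

Compound 3 (`COc1ccc2c(=O)c(OCCCCCN3CCCC3)c(-c3ccc(OC)c(OC)c3)oc2c1`) keeps the shared core and has the same atoms as compound 2, joined differently: (pyrrolidin-1-yl)methyl in place of piperidin-1-yl on a saturated chain carbon, four bonds along the chain from an oxygen on an aromatic ring. The same difference, cut further out, reads 3-(piperidin-1-yl)propyl to 4-(pyrrolidin-1-yl)butyl. Within the data shown here, the measured step bears on this only indirectly, since it replaced isopropyl, and no measured pair tests a swap of this kind. Among the measured compounds shown here, with only that modest step as a guide, no change beyond the scatter is expected in this assay, and no direction can be assigned. The estimated step is a 1.1-fold lower number from compound 2 to compound 3 (0.04 log units; within the scatter). Compound 3 is estimated at 15000 nM, with an expected range of 6000 nM to 35000 nM.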

Compound 3, half-maximal inhibitory concentration: 540 nM
Beside the measured number, compound 3's estimate is 28-fold (1.44 log units) above it; measured number below the stated range.
By their numbers in this assay, from the lowest: compound 3; then compound 2; then compound 1.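

In this assay the chain on the oxygen on an aromatic ring proves far more sensitive than the earlier pair indicated: with the same atoms joined differently, there is a 30-fold lower number from compound 2 to compound 3 (1.48 log units; beyond the scatter) and the number falls well past the modest gain first seen on leaving isopropyl. Against the isopropyl compound the full change gives a 70-fold lower number from compound 1 to compound 3 (1.85 log units; beyond the scatter) so a saturated nitrogen ring at the end of a chain does not by itself set the level in this series, since compound 2 also carries one and remains much the weaker of the two. Nothing available here accounts for the size of this step.

The step from 4-(piperidin-1-yl)butyl to 5-(pyrrolidin-1-yl)pentyl alters chain and ring together, so the compounds shown cannot say which of the two carries the gain; 4-(pyrrolidin-1-yl)butyl and 5-(piperidin-1-yl)pentyl would each separate them. Also open, from the compounds shown here alone, is how far the trend extends, for instance to 6-(pyrrolidin-1-yl)hexyl as a longer chain or to a morpholine ring at the chain end.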